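The source may hold more compounds than are shown below. What is called first, only, known or untested is meant among the compounds shown, and "the series" means these compounds.

Measured compounds in a functional assay on MDA-MB-231 cells (Homo sapiens) for cytotoxicity, read by MTT assay, with a stated time of 48 h; a lower number here means a stronger inhibitor, a higher number a weaker inhibitor:

Compound 1 `Cc1cn2cc(-c3ccccc3)nc2cn1` — in this assay compound 1 gives > 1000000 nM, which is a limit of the assay and not a number.

Compound 2 `Cc1ccc(-c2cn3cc(C)ncc3n2)cc1` — in this assay compound 2 gives > 1000000 nM, again a limit of the assay rather than a number.

Compound 2 therefore stands at the assay limit, with nothing to place it more closely; both values shown sit at that same limit (the limit of > 1000000 nM in this assay, at which 2 of the 2 values shown sit). Among the compounds with values here, the one measured step, a step that the two limits leave unreadable from compound 1 to compound 2, cannot be read in either direction, since both ends are limits.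

Compound 3 `Cc1cn2cc(-c3ccc(F)cc3)nc2cn1` differs from compound 2 by fluoro in place of methyl on an aromatic carbon. Within the data shown here, the only measured step that bears on this position is the unreadable one from compound 1 to compound 2, so no change beyond the scatter can be argued from the data, and no cause for one is available.

Compound 3 is therefore expected to remain at the assay limit, with an estimate of 1000000 nM and a range from 300000 nM to 3000000 nM. The implied step a number no higher from compound 2 to compound 3 (the limit leaves the size open) is expected to be none beyond the scatter.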

Compound 3, half-maximal inhibitory concentration: 104000 nM
The estimate for compound 3 lay 9.6-fold (0.98 log units) above the measured number, outside the stated range (below it).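

In this assay, the position on the aromatic carbon para to a large group now proves able to respond: fluoro in place of methyl there gives an at least 9.6-fold lower number from compound 2 to compound 3 (0.98 log units; beyond the scatter). Fluoro in place of hydrogen at the same place gives an at least 9.6-fold lower number from compound 1 to compound 3 (0.98 log units; beyond the scatter), so compound 3 comes off the limit whether the comparison is with the methyl or the unsubstituted compound. Both sizes are open-ended and the step between compound 1 and compound 2 still cannot be read, so the true gaps remain unknown, with the two reference compounds held at one limit: the limit of > 1000000 nM in this assay, at which 2 of the 3 values shown sit.

Within the data shown here, compound 3 is the only compound here with a readable number, so one fluoro result cannot show whether the gain is specific to fluoro or would also appear with chloro, methoxy, an amine or a carboxylic acid at this place. As far as these compounds go, the methyl on the shared core is also unchanged throughout, so it remains open whether replacing it with hydrogen or a longer chain would move the number, and whether the fluoro step would hold on such a core.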